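This account rests on a few compounds, and the source may have more. Where it says the series, first, only, none or still open, it means among the compounds named here.

Two compounds of the series have been run in a functional assay on A549 cells (Homo sapiens) for antiproliferative activity, read by MTT assay, with a stated time of 72 h; on this read-out higher numbers stand for weaker inhibition and lower numbers for stronger inhibition. Compound 1 `O=C(Nc1ccc(Oc2ccnc3[nH]ccc23)c(F)c1)c1cc2cccnc2n(-c2ccc(Br)cc2F)c1=O` gives 460 nM in this assay. Compound 2 `Cn1ccc2c(Oc3ccc(NC(=O)c4cc5cccnc5n(-c5ccc(F)c(Cl)c5)c4=O)cc3F)ccnc21` gives 3560 nM in this assay, the highest of the two numbers; compound 1 and compound 2 differ in two places, so their gap is read only as the pair of values. Compound 3 `Cn1ccc2c(Oc3ccc(NC(=O)c4cc5cccnc5n(-c5ccc(Br)cc5F)c4=O)cc3F)ccnc21` carries 4-bromo-2-fluorophenyl in place of 3-chloro-4-fluorophenyl on an aromatic nitrogen, the same aryl group that compound 1 bears. Because compound 1 gives 460 nM with this group, a downward step is expected for compound 3, of moderate size, a 2.4-fold lower number from compound 2 to compound 3 (0.38 log units; beyond the scatter). Compound 3 is therefore estimated at 1500 nM, within 500 nM to 4500 nM.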

Compound 3, half-maximal inhibitory concentration: 2690 nM
The estimate for compound 3 lay 1.8-fold (0.25 log units) below the measured number, within the range that was stated.
By their numbers in this assay, from the lowest: compound 1; then compounds 3 and 2 (each within the scatter of the next).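

With methyl held in place, exchanging 3-chloro-4-fluorophenyl for 4-bromo-2-fluorophenyl on the aromatic nitrogen gives in this assay a 1.3-fold lower number from compound 2 to compound 3 (0.12 log units; within the scatter), so these two aryl groups cannot be separated here. Among these compounds, the single change of methyl in place of hydrogen on an aromatic nitrogen gives a 5.8-fold higher number from compound 1 to compound 3 (0.77 log units; beyond the scatter), a step beyond the scatter. Nothing available explains either step.

On these data alone, whether the aryl exchange stays this flat with hydrogen in place of the methyl remains open. Also open, as far as these compounds go, is how an ethyl group or a longer chain carrying an amine would behave on that same nitrogen.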